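Swapping isobutyl for 3-methoxyphenyl on a lactam nitrogen

The source may report more compounds than this note shows. Statements on the series, on what has been measured and on what is new or still open speak of the compounds shown alone.

Three compounds have been measured in an in vitro functional assay on HEK293-A cells for negative allosteric modulation of metabotropic glutamate receptor 5 (Homo sapiens), read by FLIPR and calcium flux; on this read-out higher numbers stand for weaker inhibition and lower numbers for stronger inhibition:
compound 1 `C[C@H](c1ccccc1)N1C[C@H](c2nc(-c3cccc(Cl)c3)no2)CC1=O` gives 1600 nM;
compound 2 `CC(C)CN1CC(c2nc(-c3cccc(Cl)c3)no2)CC1=O` gives 920 nM;
compound 3 `O=c1sc2ccccc2n1Cc1nc(-c2cccc(Cl)c2)no1` gives 1100 nM.

Compound 2 gives the lowest of these three numbers, but its neighbours sit close: the gap to compound 3 lies within the scatter, and the gap to compound 1 lies within the scatter as well, so no order can be read among the three. Compound 4 `COc1cccc(N2CC(c3nc(-c4cccc(Cl)c4)no3)CC2=O)c1` has not been measured. It differs from compound 2 in one place: 3-methoxyphenyl in place of isobutyl on an amide-type nitrogen in a ring. Within the data shown here, no measured pair shows this kind of change, so there is no step to lean on. The author expects the step of a 1.4-fold lower number from compound 2 to compound 4 (0.15 log units; within the scatter) to be small, no more than the scatter, and possibly toward a lower number. In this assay compound 4 is therefore estimated at 650 nM, with a range from 150 nM to 2800 nM.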

Compound 4, half-maximal inhibitory concentration: 690 nM
The estimate for compound 4 lay 1.1-fold (0.03 log units) below the measured number; the range from low to high includes it.
By their numbers in this assay, from the lowest: compounds 4, 2, 3 and 1 (each within the scatter of the next, the first and the last beyond it).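

Placing 3-methoxyphenyl in place of isobutyl on the amide-type nitrogen in a ring gives, in this assay, a 1.3-fold lower number from compound 2 to compound 4 (0.12 log units; within the scatter). Among these compounds, this is the first step read at this position, and it shows that the nitrogen can carry a six-membered aromatic ring of carbon as well as a branched chain without a change beyond the scatter. No measurement at hand explains this similarity. As far as these compounds go, whether a plain phenyl, an amine or a carboxylic acid at this position would give a similar number remains open.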